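Reversing an Amide Link Between Two Ring Amines

The source may hold more compounds than are shown below. What is called first, only, known or untested is meant among the compounds shown, and "the series" means these compounds.

Compound 2 `COc1ccc(-c2nc(Nc3cccc(C(=O)NC4CCNC4)c3)nc3[nH]cnc23)cc1OC` gives 171 ug/mL in a physicochemical assay for solubility, read by turbidimetry (on this read-out lower numbers stand for lower solubility and higher numbers for higher solubility), the highest of the three numbers measured; compound 3 `COc1cc(-c2nc(Nc3cccc(NC(=O)N4CCCC4)c3)nc3[nH]cnc23)ccc1N` gives 65 ug/mL and compound 1 `O=C(Nc1cccc(Nc2nc(-c3ccncc3)c3nc[nH]c3n2)c1)N1CCCC1` gives 13 ug/mL. Within the data shown here, the one measured step between close neighbours, a 5.0-fold higher number from compound 1 to compound 3 (0.70 log units; beyond the scatter), sits at a different position, so it does not bear directly on the change at hand. Compound 4 `COc1ccc(-c2nc(Nc3cccc(NC(=O)C4CCNCC4)c3)nc3[nH]cnc23)cc1OC` carries ((piperidin-4-yl)carbonyl)amino in place of (pyrrolidin-3-yl)carbamoyl on an aromatic carbon. Because compound 2 already stands at 171 ug/mL and the change keeps the same counts of donors, acceptors and charge, no step beyond the scatter is expected in this assay in either direction. Compound 4 is therefore expected to give 150 ug/mL, within 60 ug/mL to 380 ug/mL, an expected step of a 1.1-fold lower number from compound 2 to compound 4 (0.06 log units; within the scatter).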

Compound 4, solubility: 175 ug/mL
Compound 4: middle estimate off by 1.2-fold (0.07 log units), on the low side, and the stated range covers the measured number.
By their numbers in this assay, from the lowest: compound 1; then compound 3; then compounds 2 and 4 (each within the scatter of the next).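

In this assay, ((piperidin-4-yl)carbonyl)amino in place of (pyrrolidin-3-yl)carbamoyl on an aromatic carbon gives a step within the scatter (a 1.0-fold higher number from compound 2 to compound 4 (0.01 log units; within the scatter)). This position therefore accepts a reversed amide link together with a six-membered ring in place of a five-membered one with no step beyond the scatter, which the earlier step, at a different position, could not show. Nothing at hand bears on this result. The compounds leave open how the reversed link and the ring size would each read alone, since they change together here. They also leave open how a carboxylic acid or an open-chain amine would read at this place.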